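Butyl ester to primary amide on a dienoate chain

This account rests on a few compounds, and the source may have more. Where it says the series, first, only, none or still open, it means among the compounds named here.

Measured compounds:
compound 1, `CCCCOC(=O)/C=C(C)/C=C/CC(C)CCCC(C)(C)OC`: 6.62
compound 2, `CCOC(=O)/C=C(C)/C=C/CC(C)CCC1OC1(C)C`: 4.76
compound 3, `C=CCSC(=O)/C=C(C)/C=C/CC(C)CCCC(C)C`: 7.97

In a physicochemical assay for lipophilicity (on this read-out lower numbers stand for lower lipophilicity and higher numbers for higher lipophilicity), compound 1 gives 6.62, the second highest of the three numbers. Compound 3 stands higher, beyond the scatter, and compound 2 stands lower, also beyond the scatter. The unmeasured compound 4, `COC(C)(C)CCCC(C)C/C=C/C(C)=C/C(N)=O`, differs from compound 1 in one place: amino in place of butoxy on a carbonyl carbon. Going by the values given here, no pair of measured compounds differs in only one place, so the size of this change has no measured counterpart here. The step from compound 1 to compound 4 is expected to be a large decrease in this assay, well beyond the scatter, namely a number 2.72 log units lower from compound 1 to compound 4 (beyond the scatter). Compound 4 is therefore estimated at 3.9, within a range of 3.2 to 4.6.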

Compound 4, partition coefficient: 3.52
Beside the measured number, compound 4's estimate is 0.38 log units above it, within the range that was stated.
By their numbers in this assay, from the lowest: compound 4; then compound 2; then compound 1; then compound 3.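

Going by these compounds alone, putting amino in place of butoxy on a carbonyl carbon gives, in this assay, a number 3.10 log units lower from compound 1 to compound 4 (beyond the scatter), the first one-place step in this set and so the first measured size for a change at this position. The change swaps a group of 5 heavy atoms and no hydrogen-bond donors for one of 1 heavy atom and 1 hydrogen-bond donor. Nothing available bears on why the step has this size. The compounds shown leave open where a methylamino group, a dimethylamino group or a carboxylic acid on that carbonyl carbon would stand. They also leave open whether the same change would give a similar step on the chains of compound 2 or compound 3.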